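The source may hold more compounds than are shown below. What is called first, only, known or untested is meant among the compounds shown, and "the series" means these compounds.

Compound 2 `CCC/N=C1\S/C(=C\c2ccc(O)c(Br)c2)C(=O)N1c1ccccc1C` gives 79000 nM in a physicochemical assay for solubility, measured as kinetic solubility (on this read-out higher numbers stand for higher solubility and lower numbers for lower solubility), and stands level with compound 1 `CCC/N=C1\S/C(=C\c2ccc(O)c(Cl)c2)C(=O)N1C1CC1` at 79000 nM, the two together the highest of the three numbers; compound 3 `CCC/N=C1\S/C(=C\c2ccc(O)c(Cl)c2)C(=O)N1C1CCOCC1` gives 70000 nM and is the furthest from compound 2. For the measured compounds named here, the only single-change step measured, a 1.1-fold lower number from compound 1 to compound 3 (0.05 log units; within the scatter), touches the amide-type nitrogen in the ring and lies within the scatter. Compound 4 `CCC/N=C1\S/C(=C\c2ccc(O)cn2)C(=O)N1c1ccccc1C` differs from compound 2 by 5-hydroxypyridin-2-yl in place of 3-bromo-4-hydroxyphenyl on a double-bonded chain carbon bound to a double-bonded ring carbon. Going by the values given here, no measured step alters the group on the double-bonded chain carbon, so none bears directly on this change. With nothing to point either way, the number for compound 4 is expected close to compound 2, an estimated 1.3-fold higher number from compound 2 to compound 4 (0.10 log units; within the scatter) with a wide range. Compound 4 is therefore estimated at 100000 nM, between 40000 nM and 250000 nM.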

Compound 4, solubility: 110000 nM
Estimate against measurement, compound 4: 1.1-fold (0.04 log units) below, and the stated range covers the measured number.
By their numbers in this assay, from the lowest: compounds 3, 1, 2 and 4 (each within the scatter of the next).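

In this assay, the group on the double-bonded chain carbon now has its first measured step, 5-hydroxypyridin-2-yl in place of 3-bromo-4-hydroxyphenyl (a 1.4-fold higher number from compound 2 to compound 4 (0.14 log units; within the scatter)). For the compounds shown here, exchanging the carbon-only aromatic ring and its bromine for a ring with one hetero atom thus leaves the read-out within the scatter, as does the only step at the amide-type nitrogen in the ring (a 1.1-fold lower number from compound 1 to compound 3 (0.05 log units; within the scatter)). No measurement at hand accounts for this result.

From the compounds shown here alone, whether an amine or a carboxylic acid on the 5-hydroxypyridin-2-yl ring would move the number beyond the scatter stays open. Also open, going by these compounds, is whether 5-hydroxypyridin-2-yl gives a similar number with cyclopropyl or oxan-4-yl on the amide-type nitrogen in the ring.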